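Thiourea amide series: chloro-to-fluoro swap at the anilide

This account rests on a few compounds, and the source may have more. Where it says the series, first, only, none or still open, it means among the compounds named here.

Two members of this series have numbers in a functional assay on PC-3 cells (Homo sapiens) for cytotoxicity, read by sulforhodamine B assay, with a stated time of 48 h (a higher number here means a weaker inhibitor of growth, a lower number a stronger inhibitor of growth), so far. Compound 1 `CC1=C(C(=O)Nc2ccc(F)c(Cl)c2)C(c2cccc(Oc3ccccc3)c2)NC(=S)N1` gives 12000 nM in this assay. Compound 2 `COc1cccc(C2NC(=S)NC(C)=C2C(=O)Nc2ccc(Cl)c(Cl)c2)c1` gives 14500 nM in this assay, the higher of the two numbers, but the gap to compound 1 lies within the scatter of repeated measurements, so the two numbers show no difference that can be read. Within the data shown here, no pair of measured compounds differs in a single place, and no computed step is available.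

Compound 3 `COc1cccc(C2NC(=S)NC(C)=C2C(=O)Nc2ccc(F)c(Cl)c2)c1` is the next compound to be run in this assay. It differs from compound 2 by fluoro in place of chloro on an aromatic carbon, with the rest of the structure held the same.

Among the measured compounds shown here, no measured step speaks to this change directly. For the measured compounds named here, the only guidance is that compound 1, which already carries the 3-chloro-4-fluorophenyl amide, gives 12000 nM, close to compound 2. The step from compound 2 to compound 3 is therefore expected to be a 1.1-fold lower number from compound 2 to compound 3 (0.05 log units; within the scatter), a change of no more than the scatter in either direction. Compound 3 is expected to give about 13000 nM in this assay, with a range from 6000 nM to 30000 nM.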

Compound 3, concentration for 50% growth inhibition: 23400 nM
Beside the measured number, compound 3's estimate is 1.8-fold (0.26 log units) below it; the range from low to high includes it.
By their numbers in this assay, from the lowest: compounds 1, 2 and 3 (each within the scatter of the next).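

In this assay, the change from 3,4-dichlorophenyl to 3-chloro-4-fluorophenyl on the amide nitrogen gives a 1.6-fold higher number from compound 2 to compound 3 (0.21 log units; within the scatter), so this first single-place comparison shows no readable effect of fluoro in place of chloro while the rest of the structure stays the same. The second comparison, methyl in place of phenyl on an oxygen on an aromatic ring with the 3-chloro-4-fluorophenyl amide held constant, gives a 2.0-fold higher number from compound 1 to compound 3 (0.29 log units; within the scatter) and likewise shows no readable effect at that oxygen. Nothing shown bears on the reason for these numbers.

On these data alone, all three compounds carry a chloro group and a second halogen on the anilide ring, so it remains open whether an amine, a nitrile or a carboxylic acid in place of the fluoro would shift the number in this assay beyond the scatter. As far as these compounds go, it also remains open whether a benzyl group or a longer chain on the oxygen would give a readable step from either the methyl or the phenyl group.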